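The compounds below may be only part of what the source reports. "The series", "measured", "known", "first", "only" and "open" are said of these compounds alone.

Measured so far:
compound 1, `CC(C)(C)OC(=O)NCCNC(=O)CN1CN(c2ccccc2)C2(CCN(C(=O)c3ccc(C(C)(C)C)cc3)CC2)C1=O`, 10900 nM
compound 2, `CS(=O)(=O)N1CCN(C(=O)CN2CN(c3ccccc3)C3(CCN(C(=O)c4ccc(C5CCCCC5)cc4)CC3)C2=O)CC1`, 6300 nM

In an assay on HEK293 cells for displacement of a labelled ligand from NPC1-like intracellular cholesterol transporter 1 (Homo sapiens) (a higher number here means a weaker inhibitor, a lower number a stronger inhibitor), compound 1 has the top of these two numbers, but its gap to compound 2 lies within the scatter, so neither compound can be called weaker or stronger than the other. Compound 3 `CC(C)(C)c1ccc(C(=O)N2CCC3(CC2)C(=O)N(CC(=O)NCCCNS(C)(=O)=O)CN3c2ccccc2)cc1` is compound 1 with one change: (methanesulfonamido)methyl in place of (tert-butoxycarbonyl)amino on a saturated chain carbon, two bonds along the chain from an amide-type nitrogen. Among the measured compounds shown here, no measured pair shows this change on its own, so its size is unknown; the step is expected to stay within the scatter, with no clear direction, as a 1.4-fold lower number from compound 1 to compound 3 (0.13 log units; within the scatter). Compound 3 is therefore expected to give about 8000 nM in this assay, within 3000 nM to 25000 nM.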

Compound 3, half-maximal inhibitory concentration: 10400 nM
Compound 3: the middle estimate sits 1.3-fold (0.11 log units) below what was measured; low and high end bracket the measured number.
By their numbers in this assay, from the lowest: compounds 2, 3 and 1 (each within the scatter of the next).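

In this assay, placing (methanesulfonamido)methyl where (tert-butoxycarbonyl)amino stood, on this saturated chain carbon, gives a 1.0-fold lower number from compound 1 to compound 3 (0.02 log units; within the scatter). Among the compounds shown here, this is the first single-place comparison at this position, and it shows that these two different groups cannot be told apart here, even though one contains sulfur and the other does not. Nothing measured explains why the number holds.

Going by these compounds, both groups carry no net charge, so it remains open how an amine or a carboxylic acid would read at this position. On these data alone, a longer chain also remains open.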